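Hydroxy in place of chloro: expected effect on K562 growth

A few compounds are considered here, and "the series" means these few. Any claim that something is new, unique, unknown or untested is made for them only; others in the source may bear on it.

Three hydrazones on a shared core have been run in a functional assay on K562 cells (Homo sapiens) for antiproliferative activity, read by cell counting, with a stated time of 7 days; a higher number here means a weaker inhibitor, a lower number a stronger inhibitor. Compound 2 `O=C(N/N=C/c1cc(Cl)ccc1O)c1cc2ccccc2o1` gives 3700 nM in this assay. Compound 1 `COc1cc(/C=N/NC(=O)c2cc3ccccc3o2)ccc1O` gives 5600 nM, and compound 3 `O=C(N/N=C/c1ccc(O)c(O)c1O)c1cc2ccccc2o1` gives 6000 nM; both numbers fall within the usual scatter of the value for compound 2, so the three stand level, with no ordering that the data support.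

Compound 4 `O=C(N/N=C/c1cc(O)ccc1O)c1cc2ccccc2o1` is the next member. Compared with compound 2 the change is hydroxy in place of chloro on an aromatic carbon. Among the measured compounds shown here, no measured pair in the set shows the effect of this single swap, so the size of the step is not known directly. For the measured compounds named here, the two hydroxy-bearing analogues offer the only guide: compound 1 with 5600 nM and compound 3 with 6000 nM both sit within the scatter of compound 2, which argues for a step in this assay of no size beyond the scatter, in either direction. The expected step of a 1.2-fold higher number from compound 2 to compound 4 (0.09 log units; within the scatter) is therefore a level one. Compound 4 is estimated at 4500 nM, within a range of 2000 nM to 10000 nM.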

Compound 4, half-maximal inhibitory concentration: 36800 nM
The estimate for compound 4 lay 8.2-fold (0.91 log units) below the measured number, outside the stated range (above it).
By their numbers in this assay, from the lowest: compounds 2, 1 and 3 (each within the scatter of the next); then compound 4.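

In this assay, among the compounds shown here, the carbon para to a hydroxy group does not tolerate every substituent equally: hydroxy in place of chloro gives a 9.9-fold higher number from compound 2 to compound 4 (1.00 log units; beyond the scatter) and is the first single-place step. The level numbers of the three earlier compounds, none of which forms a single-place pair with another, gave no sign that this position could register such a change. No measurement at hand bears on the reason for this step.

On these data alone, it remains open whether the step reflects the departure of chloro or the arrival of hydroxy; fluoro, methyl or an amine on the same carbon would help separate the two. Also unresolved is whether the same swap gives a step of similar size at other carbons of this ring.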